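Efficacy Estimate for Compound 3 from Two Measured Analogs

A few compounds are considered here, and "the series" means these few. Any claim that something is new, unique, unknown or untested is made for them only; others in the source may bear on it.

compound 1, `O=C(O)Cc1sc(C(c2ccc(F)cc2)c2ccc(F)cc2)nc1-c1ccccc1`: 80%
compound 2, `Cc1cc(-c2nc(C(c3ccc(F)cc3)c3ccc(F)cc3)sc2CC(=O)O)cnc1N`: 80%

In an in vitro functional assay on HEK285-7 cells for antagonist activity at prostaglandin D2 receptor 2 (Homo sapiens), read by BRET and beta-arrestin recruitment (on this read-out higher numbers stand for larger maximal responses and lower numbers for smaller maximal responses), compound 1 reaches 80%, and compound 2 reaches 80%. Going by the values given here, the one measured step, no change at the digits printed from compound 1 to compound 2 (within the scatter), puts 6-amino-5-methylpyridin-3-yl in place of phenyl on an aromatic carbon of the shared core, and it left the largest response unchanged within the scatter. Compound 2 therefore stands level with compound 1 on these numbers; neither can be called the more efficacious.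

Compound 3, `CN(C)c1cc(-c2nc(C(c3ccc(F)cc3)c3ccc(F)cc3)sc2CC(=O)O)ccn1`, is the next member, and it has not yet been measured in this assay. Its difference from compound 2 is 2-(dimethylamino)pyridin-4-yl in place of 6-amino-5-methylpyridin-3-yl on an aromatic carbon. Among the compounds with values here, the only step that bears on this change is the earlier exchange of the aromatic group at the same place, no change at the digits printed from compound 1 to compound 2 (within the scatter), which was flat. With no other guide, the expected step of no change at the digits printed from compound 2 to compound 3 (within the scatter) is estimated to lie within the scatter, in no particular direction. Compound 3 is therefore expected to give about 80% in this assay, with a range of 66% to 92%.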

Compound 3, largest response reached (reported as efficacy), in percent of the reference or control that the assay uses: 80%
The estimate for compound 3 equals the measured number at the digits printed; the range from low to high includes it.
By their numbers in this assay, from the lowest: compounds 1, 2 and 3 (each within the scatter of the next).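

With the step to 2-(dimethylamino)pyridin-4-yl, no change at the digits printed from compound 2 to compound 3 (within the scatter) in this assay, the position on the aromatic carbon next to the ring nitrogen has now taken a second exchange between two substituted pyridines, and the largest response stayed level. This exchange differs from the first. It replaces one pyridine with another, moving from a group with 1 hydrogen-bond donor to one with 0 donors, and that change in count did not separate the two compounds on this read-out. Measured against the phenyl group, the same replacement gives no change at the digits printed from compound 1 to compound 3 (within the scatter), so all three groups at this place sit together within the scatter, although the data offer no explanation for that flatness.

The compounds shown leave open whether a group without an aromatic ring at this place, such as cyclohexyl or a short alkyl chain, would keep the response level in this assay. They also leave open whether a pyridine bearing a carboxylic acid or a longer aminoalkyl chain would separate from these three.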